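Swapping a pyridine attachment point in a cytotoxicity series

The source may hold more compounds than are shown below. What is called first, only, known or untested is meant among the compounds shown, and "the series" means these compounds.

Measured compounds:
compound 1, `C[C@@H](NC(=O)[C@H](CCCNC(=N)N)NC(=O)c1ccc(CN(Cc2cccnc2)C(=O)c2ccc(F)cc2)cc1)c1cccc2ccccc12`, 45000 nM
compound 2, `C[C@H](NC(=O)[C@H](CCCNC(=N)N)NC(=O)c1ccc(CN(Cc2ccc(F)cc2)Cc2cccnc2)cc1)c1cccc2ccccc12`, 41000 nM
compound 3, `C[C@H](NC(=O)[C@H](CCCNC(=N)N)NC(=O)c1ccc(CN(Cc2ccccn2)C(=O)c2ccc(F)cc2)cc1)c1cccc2ccccc12`, 37000 nM

All three were tested in an ADME assay on MT4 cells (Homo sapiens) for cytotoxicity; on this read-out higher numbers stand for lower toxicity in this test and lower numbers for higher toxicity in this test. Compound 3 gives 37000 nM, the lowest of the three numbers, but its gaps to compound 2 and to compound 1 both lie within the usual scatter, so the three compounds cannot be told apart on toxicity here.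

Compound 4, `C[C@H](NC(=O)[C@H](CCCNC(=N)N)NC(=O)c1ccc(CN(Cc2cccnc2)C(=O)c2ccc(F)cc2)cc1)c1cccc2ccccc12`, differs from compound 3 in a single place: pyridin-3-yl in place of pyridin-2-yl on a saturated chain carbon bound to an amide-type nitrogen. Nothing measured tells how this change moves the read-out. Since the three measured compounds sit together in a narrow band, the expected step of a 1.1-fold higher number from compound 3 to compound 4 (0.03 log units; within the scatter) is none beyond the scatter. Compound 4 is therefore expected to give about 40000 nM, most likely between 20000 nM and 80000 nM.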

Compound 4, half-maximal cytotoxic concentration: 57000 nM
Beside the measured number, compound 4's estimate is 1.4-fold (0.15 log units) below it; low and high end bracket the measured number.
By their numbers in this assay, from the lowest: compounds 3, 2, 1 and 4 (each within the scatter of the next).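

In this assay, pyridin-3-yl in place of pyridin-2-yl on this saturated chain carbon gives a step that stays within the scatter (a 1.5-fold higher number from compound 3 to compound 4 (0.19 log units; within the scatter)). Two other single changes also stay within it: (4-fluorophenyl)carbonyl in place of 4-fluorobenzyl on an amine nitrogen (a 1.4-fold higher number from compound 2 to compound 4 (0.14 log units; within the scatter)), and the opposite configuration at a stereocentre on a saturated chain carbon (a 1.3-fold higher number from compound 1 to compound 4 (0.10 log units; within the scatter)). Nothing at hand gives a reason for any of these steps.

Still open, from the compounds shown here alone, is whether pyridin-4-yl, or a carboxylic acid, on this carbon would shift the number beyond the scatter.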